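A few compounds are considered here, and "the series" means these few. Any claim that something is new, unique, unknown or untested is made for them only; others in the source may bear on it.

Compound 1 `CCCSc1cc(C)c(C(=O)N=C(N)N)cc1S(C)(=O)=O` gives 6.8 nM.
Compound 2 `Cc1cc(Sc2ccccc2)c(S(C)(=O)=O)cc1C(=O)N=C(N)N` gives 14 nM.
Compound 3 `Cc1cc(OC(C)(C)C)c(S(C)(=O)=O)cc1C(=O)N=C(N)N` gives 9.4 nM.

In a functional assay for inhibition of sodium/hydrogen exchanger (Oryctolagus cuniculus) (on this read-out higher numbers stand for weaker inhibition and lower numbers for stronger inhibition), the three measured compounds sit close together. Compound 3 has the second highest number of the three, yet its gaps to compound 1 and to compound 2 both fall within the usual scatter, so no order among them can be claimed. Compound 4 `Cc1cn(-c2cc(C)c(C(=O)N=C(N)N)cc2S(C)(=O)=O)cn1` differs from compound 3 in one place: 4-methyl-1H-imidazol-1-yl in place of tert-butoxy on an aromatic carbon. Earlier changes at this same aromatic carbon moved little: a 1.4-fold higher number from compound 1 to compound 3 (0.14 log units; within the scatter) and a 1.5-fold lower number from compound 2 to compound 3 (0.17 log units; within the scatter). Among the measured compounds shown here, the only step beyond the scatter, a 2.1-fold higher number from compound 1 to compound 2 (0.31 log units; beyond the scatter), was modest. On this basis the step from compound 3 to compound 4 is expected to be small, a 1.4-fold higher number from compound 3 to compound 4 (0.14 log units; within the scatter). Compound 4 is therefore estimated at 13 nM, with a range from 5 nM to 35 nM.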

Compound 4, half-maximal inhibitory concentration: 28 nM
Compound 4: the middle estimate sits 2.2-fold (0.33 log units) below what was measured; the range from low to high includes it.
By their numbers in this assay, from the lowest: compounds 1, 3, 2 and 4 (each within the scatter of the next, the first and the last beyond it).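

Among the compounds shown here, this aromatic carbon, ortho to the methylsulfonyl group, is less forgiving than the earlier compounds suggested: this assay shows a 3.0-fold higher number from compound 3 to compound 4 (0.47 log units; beyond the scatter) and a 4.1-fold higher number from compound 1 to compound 4 (0.61 log units; beyond the scatter), both beyond the scatter. The ring-bearing phenylsulfanyl group cannot be told apart from the 4-methyl-1H-imidazol-1-yl group, with a 2.0-fold higher number from compound 2 to compound 4 (0.30 log units; within the scatter) inside the scatter. Nothing available here accounts for these steps. Still open, from the compounds shown here alone, is how a plain imidazol-1-yl, a dimethylamino group or a carboxylic acid on this carbon would compare.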